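The compounds below may be only part of what the source reports. "The series", "measured", "known", "first", "only" and "open" are said of these compounds alone.

Compound 1 `COc1ccc(S(=O)(=O)NCCN2CCC(CCC(=O)c3cc(Cl)c(N)cc3OC)CC2)cc1` gives 36% in an assay on HEK293 cells for displacement of a labelled ligand from 5-hydroxytryptamine receptor 6 (Homo sapiens), with a stated time of 60 min, tested at 0.01 uM, in the presence of a further agent that is not named here (a higher number here means a stronger effect of the compound at the concentration tested, a lower number a weaker effect), the highest of the two numbers recorded in the series; compound 2 `COc1cc(N)c(Cl)cc1C(=O)CCC1CCN(CCNS(=O)(=O)c2ccc(OC)c(N3CCN(C)CC3)c2)CC1` gives 4%, and compound 3 `COc1ccc(S(=O)(=O)NCCCN2CCC(CCC(=O)c3cc(Cl)c(N)cc3OC)CC2)cc1` is reported as "not active" (no number reported) with no number. Going by the values given here, the single counted step, a number 32 percentage points lower from compound 1 to compound 2 (beyond the scatter), concerns a different group. Compound 4 `COc1cc(N)c(Cl)cc1C(=O)CCC1CCN(CCNS(=O)(=O)c2ccc(NC(C)=O)cc2)CC1` differs from compound 1 as follows: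

acetamido in place of methoxy on an aromatic carbon

Among the compounds with values here, no measured step covers this exchange of 4-methoxyphenyl for 4-acetamidophenyl. Within the data shown here, the step from compound 1 to compound 2 shows only that a change on that part of the molecule can be large. A moderate loss is therefore expected, a number 11 percentage points lower from compound 1 to compound 4 (beyond the scatter), with wide uncertainty. Compound 4 is estimated at 25% in this assay, between 5% and 45%.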

Compound 4, a percentage reported as inhibition, at one concentration (the size of the read-out at that concentration, not a potency): 7%
Compound 4: middle estimate off by 18 percentage points, on the high side, and the stated range covers the measured number.
By their numbers in this assay, from the lowest: compounds 2 and 4 (each within the scatter of the next); then compound 1.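

Acetamido in place of methoxy, para to a large group, gives a number 29 percentage points lower from compound 1 to compound 4 (beyond the scatter) in this assay. The methoxy position itself is therefore sensitive to exchange, whereas the earlier step, a number 32 percentage points lower from compound 1 to compound 2 (beyond the scatter), kept the methoxy and placed 4-methylpiperazin-1-yl on another aromatic carbon. No available measurement bears on the origin of this loss.

On these data alone, it remains open whether a smaller group at this position, such as an amine, hydroxy or fluorine, would hold the read-out at the level of compound 1 36%. As far as these compounds go, it is also open whether a simple ethoxy would do so.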